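The source may hold more compounds than are shown below. What is called first, only, known or untested is meant among the compounds shown, and "the series" means these compounds.

Measured so far in a functional assay on A-375 cells (Homo sapiens) for antiproliferative activity, read by CCK-8 assay, with a stated time of 72 h, tested at 2 uM; a lower number here means a weaker effect, a higher number a stronger effect of the compound at the concentration tested:

- compound 1 `Nc1ccccc1NC(=O)c1ccc(CSC(=S)N2CCc3ccccc32)cc1`: 25.7%
- compound 2 `Nc1ccccc1NC(=O)c1ccc(CSC(=S)N2CCCc3ccccc32)cc1`: 26.5%

Compound 1 stands lowest of the two numbers in this assay, though compound 2 sits within the scatter of it, so the two cannot be ordered. Within the data shown here, the one measured step, a number 0.8 percentage points higher from compound 1 to compound 2 (within the scatter), concerns the ring on the thiocarbonyl carbon and lay within the scatter.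

Compound 3 `Nc1ccccc1NC(=O)c1ccc(CSC(=S)N2CCc3ccc([N+](=O)[O-])cc32)cc1` is the next compound in line. It differs from compound 1 by nitro in place of hydrogen on an aromatic carbon. Among the measured compounds shown here, no measured step touches this position or this group, so the step from compound 1 to compound 2 gives only a general sense of how little the read-out moved within this set, and nothing that speaks directly to a nitro group. Absent such a step, compound 3 is expected to land near compound 1, with a wide range to cover the unknown.

The estimate for compound 3 in this assay is 28%, between 12% and 48%, which is expected to mean a number 2.3 percentage points higher from compound 1 to compound 3 (within the scatter).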

Compound 3, a percentage reported as inhibition, at one concentration (the size of the read-out at that concentration, not a potency): 22.1%
Compound 3: middle estimate off by 5.9 percentage points, on the high side; low and high end bracket the measured number.
By their numbers in this assay, from the lowest: compounds 3, 1 and 2 (each within the scatter of the next).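

In this assay, nitro in place of hydrogen on an aromatic carbon gave a number 3.6 percentage points lower from compound 1 to compound 3 (within the scatter). Among these compounds, this is the first look at a substituent on this aromatic ring of the shared core, and so large a group as nitro, with its three heavy atoms, left the read-out within the scatter of the hydrogen-bearing compound 1. Like the ring change on the thiocarbonyl carbon, this change therefore does not separate the compounds at the single concentration tested. Nothing available here bears on why the read-out held so close.

As far as these compounds go, it remains open whether an amine, a methoxy group or a chlorine atom on this same carbon would move the read-out beyond the scatter. The same question stands for a nitro group on the other carbons of this ring.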